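The source may hold more compounds than are shown below. What is called first, only, known or untested is meant among the compounds shown, and "the series" means these compounds.

Compound 3 `CCc1cc(C#N)ccc1C/N=c1\c(O)c(O)\c1=N/C(C)(C)CC` gives 110 nM in a functional assay for inhibition, with Rattus norvegicus as the target; a higher number here means a weaker inhibitor, a lower number a stronger inhibitor. Compound 1 `CCc1cc(C#N)ccc1C/N=c1\c(O)c(O)\c1=N/C(C)(C)C` differs from it by hydrogen in place of methyl on a saturated chain carbon, two bonds along the chain from a double-bonded nitrogen; this change gives a 2.2-fold higher number from compound 3 to compound 1 (0.34 log units; beyond the scatter), and in this assay compound 1 gives 240 nM. Compound 2 `CCC(C)(C)/N=c1\c(O)c(O)\c1=N/Cc1ccc(C)cc1C` carries the 1,1-dimethylpropyl group on another core; the difference between the two cores is not broken down here. In this assay compound 2 gives 530 nM, the highest of the three numbers. Compound 4 `Cc1ccc(C/N=c2\c(O)c(O)\c2=N/C(C)(C)C)c(C)c1` differs from compound 2 by hydrogen in place of methyl on a saturated chain carbon, two bonds along the chain from a double-bonded nitrogen, the same change as from compound 3 to compound 1, at the same place. Because that change gave a 2.2-fold higher number from compound 3 to compound 1 (0.34 log units; beyond the scatter) on the core of compound 3, the step from compound 2 to compound 4 is expected to be a 2.2-fold higher number from compound 2 to compound 4 (0.34 log units; beyond the scatter) in this assay, resting on that single precedent. Compound 4 is therefore expected to give about 1170 nM, between 600 nM and 2300 nM, in this assay.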

Compound 4, half-maximal inhibitory concentration: 630 nM
Beside the measured number, compound 4's estimate is 1.9-fold (0.27 log units) above it, and the stated range covers the measured number.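

In this assay, the change from 1,1-dimethylpropyl to tert-butyl gives a 1.2-fold higher number from compound 2 to compound 4 (0.08 log units; within the scatter), so on this core the step does not stand clear of the scatter. Set beside the earlier step, it does not differ by more than repeat measurements allow: the same change on two cores in this assay, a 2.2-fold higher number (0.34 log units; beyond the scatter) from compound 3 to compound 1 and a 1.2-fold higher number (0.08 log units; within the scatter) from compound 2 to compound 4, 1.8-fold (0.26 log units) apart, within the scatter of two such steps. The change therefore carries between these two cores without a detectable difference in step size, but this single comparison does not show that the two steps are equal or fix a size for the step on any other core.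

Still open, from the compounds shown here alone, is how a longer chain, or a chain ending in an amine or a carboxylic acid, would read in place of tert-butyl. Also open, going by these compounds, is how the difference between the two cores breaks down, group by group.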